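Adding Bromo to the Anilino Ring of Compound 2

A few compounds are considered here, and "the series" means these few. Any claim that something is new, unique, unknown or untested is made for them only; others in the source may bear on it.

Measured so far in a functional assay on PC-3 cells (Homo sapiens) for cytotoxicity, read by MTT assay, with a stated time of 72 h; on this read-out lower numbers stand for stronger inhibition and higher numbers for weaker inhibition:
Compound 1 `CCCCCCNc1nc(SCc2ccc(C(F)(F)F)cc2)nc2ccccc12`: 19000 nM
Compound 2 `FC(F)(F)c1ccc(CSc2nc(Nc3ccccc3)c3ccccc3n2)cc1`: 20000 nM
Compound 3 `FC(F)(F)c1ccc(CSc2nc(Nc3ccccc3Cl)c3ccccc3n2)cc1`: 20400 nM

In this assay compound 2 holds the second highest of the three numbers, yet all three lie within the scatter of one another. Compound 4 `FC(F)(F)c1ccc(CSc2nc(Nc3cccc(Br)c3)c3ccccc3n2)cc1` differs from compound 2 by bromo in place of hydrogen on an aromatic carbon. The most telling measured step is a 1.0-fold higher number from compound 2 to compound 3 (0.01 log units; within the scatter), which also added a single halogen to the anilino ring and stayed within the scatter. The steps of a 1.1-fold higher number from compound 1 to compound 2 (0.02 log units; within the scatter) and a 1.1-fold higher number from compound 1 to compound 3 (0.03 log units; within the scatter) show the same flatness. In this assay no step beyond the scatter is therefore expected. The expected step is no change at the digits printed from compound 2 to compound 4 (within the scatter). For compound 4 the estimated value is 20000 nM, with an expected range from 10000 nM to 40000 nM.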

Compound 4, half-maximal inhibitory concentration: 8680 nM
For compound 4 the middle estimate is 2.3-fold (0.36 log units) above the measured one; the whole stated range lies above it.
By their numbers in this assay, from the lowest: compound 4; then compounds 1, 2 and 3 (each within the scatter of the next).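

In this assay, among the compounds shown here, bromo in place of hydrogen gives a 2.3-fold lower number from compound 2 to compound 4 (0.36 log units; beyond the scatter) and is the first change here to pass the scatter, whereas hexyl, phenyl and 2-chlorophenyl on the nitrogen gave numbers within the scatter of one another. Compound 4 also stands apart from the other two, with a 2.4-fold lower number from compound 3 to compound 4 (0.37 log units; beyond the scatter) and a 2.2-fold lower number from compound 1 to compound 4 (0.34 log units; beyond the scatter) of similar modest size. Nothing available explains this shift. Still open, going by these compounds, is whether chloro at this same place would match bromo, and whether a methoxy group or an amine there would lower the number further.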